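Acid series: chlorobenzyl in place of isopentyl

This account rests on a few compounds, and the source may have more. Where it says the series, first, only, none or still open, it means among the compounds named here.

Among the compounds with values here, compound 3 `CC(C)CCn1cc(/C=C/C(=O)CC(=O)C(=O)O)c2ccccc21` is the one member of the series with a number in an assay on isolated protein for inhibition of DNA nucleotidylexotransferase (Homo sapiens), read by scintillation counting, with a stated time of 10 min; a higher number here means a weaker inhibitor, a lower number a stronger inhibitor; compound 3 gives 16.3 uM. The ethyl ester compound 1 `CCOC(=O)C(=O)CC(=O)/C=C/c1cn(CCC(C)C)c2ccccc12` gives > 40 uM, a limit of the assay. Compound 2 `CCOC(=O)C(=O)CC(=O)/C=C/c1cn(Cc2ccc(C#N)cc2)c2ccccc12` likewise gives > 40 uM, also a limit. The step of an at least 2.4-fold lower number from compound 1 to compound 3 (0.38 log units; beyond the scatter) is the only one readable in full. Compound 4 `O=C(/C=C/c1cn(Cc2ccc(Cl)cc2)c2ccccc12)CC(=O)C(=O)O` differs from compound 3 by 4-chlorophenyl in place of isobutyl on a saturated chain carbon bound to an aromatic nitrogen. The closest measured precedent, a step that the two limits leave unreadable from compound 1 to compound 2, is masked by the limit of > 40 uM in this assay, at which 2 of the 3 values shown sit, so no size can be read for an aryl in place of the branched chain in this assay. No step beyond the scatter is therefore expected. Compound 4 is estimated at 12 uM, between 4 uM and 40 uM. This amounts to an expected step of a 1.4-fold lower number from compound 3 to compound 4 (0.13 log units; within the scatter).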

Compound 4, concentration for 50% inhibition: 10 uM
Beside the measured number, compound 4's estimate is 1.2-fold (0.08 log units) above it, and the stated range covers the measured number.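

On the acid core, the saturated chain carbon bound to an aromatic nitrogen now gives a readable comparison in this assay: isopentyl to 4-chlorobenzyl is a 1.6-fold lower number from compound 3 to compound 4 (0.21 log units; within the scatter). An aromatic ring therefore stands in place of the branched chain with no shift beyond the scatter. The matching ester step cannot be read: the limit of > 40 uM in this assay, at which 2 of the 4 values shown sit.

From the compounds shown here alone, whether the chlorine matters stays open, since an unsubstituted benzyl group on the acid core has no number here. Going by these compounds, a longer chain or a chain ending in an amine at this position also remains untested in this set.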